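The compounds below may be only part of what the source reports. "The series", "measured", "known", "first", "only" and "open" are said of these compounds alone.

Three compounds have been measured in a functional assay on FM3A cells (Mus musculus) for antiproliferative activity, with a stated time of 48 h; on this read-out higher numbers stand for weaker inhibition and lower numbers for stronger inhibition:

- Compound 1 `C=C(Br)C(=O)Nc1ccc(/C=C/C(=O)c2ccc(F)cc2)cc1` gives 1200 nM
- Compound 2 `C=C(Br)C(=O)Nc1ccc(/C=C/C(=O)c2ccc(Cl)c(Cl)c2)cc1` gives 3200 nM
- Compound 3 `C=C(Br)C(=O)Nc1ccc(/C=C/C(=O)c2ccc(Br)cc2)cc1` gives 1100 nM

Compound 2 has the highest number of the three, with a 2.7-fold higher number from compound 1 to compound 2 (0.43 log units; beyond the scatter) and a 2.9-fold lower number from compound 2 to compound 3 (0.46 log units; beyond the scatter). The next step leads to compound 4 `Nc1ccc(/C=C/C(=O)c2ccc(Cl)c(Cl)c2)cc1` and is hydrogen in place of (1-bromoethenyl)carbonyl on a nitrogen on an aromatic ring, which means hydrogen in place of (1-bromoethenyl)carbonyl on a nitrogen on an aromatic ring.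

The measured steps bear on this only indirectly. All of them change the substituted phenyl on a carbonyl carbon, while the (1-bromoethenyl)carbonyl stays in place. Beside the two modest steps above, the third is a 1.1-fold lower number from compound 1 to compound 3 (0.04 log units; within the scatter). Going by the values given here, no measured compound lacks the group, so its loss has no direct measure. Since compound 4 gives up a group shared by all three measured compounds, a step larger than a 2.9-fold lower number from compound 2 to compound 3 (0.46 log units; beyond the scatter) is expected in this assay, towards a higher number. The expected step is a 4.7-fold higher number from compound 2 to compound 4 (0.67 log units; beyond the scatter). For compound 4 the estimated value is 15000 nM, with an expected range from 5000 nM to 50000 nM.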

Compound 4, half-maximal inhibitory concentration: 33000 nM
The estimate for compound 4 lay 2.2-fold (0.34 log units) below the measured number; measured number inside the range.
By their numbers in this assay, from the lowest: compounds 3 and 1 (each within the scatter of the next); then compound 2; then compound 4.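

In this assay, hydrogen in place of (1-bromoethenyl)carbonyl on a nitrogen on an aromatic ring gives a 10-fold higher number from compound 2 to compound 4 (1.01 log units; beyond the scatter), the first direct measure of what this group contributes. Going by these compounds alone, this step is larger than any of the steps among the earlier compounds, all of which changed only the substituted phenyl on a carbonyl carbon, so the change at this nitrogen counts for more in this set than those changes did. Nothing measured here accounts for the size of the step.

Because the whole group leaves at once, the compounds shown do not separate the parts played by its bromine, its double bond and its carbonyl, which a plain acetyl or a propenoyl on the same nitrogen could begin to do. Going by these compounds, the step also rests on a single pair, so it remains open whether the amino counterparts of compound 1 and compound 3 would follow it.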